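A few compounds are considered here, and "the series" means these few. Any claim that something is new, unique, unknown or untested is made for them only; others in the source may bear on it.

Measured values in a functional assay on HCT-116 cells (Homo sapiens) for cytotoxicity, with a stated time of 48 h; on this read-out higher numbers stand for weaker inhibition and lower numbers for stronger inhibition:
- compound 1 (`COc1cc(OC)c(C(=O)/C=C/c2ccccc2OC)c(OC)c1`): (4200 nM)
- compound 2 (`COc1cccc(/C=C/C(=O)c2c(OC)cc(OC)cc2OC)c1`): (4300 nM)

Among the measured compounds shown here, compound 1 has the lowest number of the two, but it cannot be ranked apart from compound 2, as the only measured step (a 1.0-fold higher number from compound 1 to compound 2 (0.01 log units; within the scatter)) lies within the scatter. Compound 3 (`COc1cc(O)c(C(=O)/C=C/c2ccccc2OC)c(OC)c1`) carries hydrogen in place of methyl on an oxygen on an aromatic ring, that is, methoxy to hydroxy. For the measured compounds named here, no measured step covers this change. Going by the values given here, the one available step, 3-methoxyphenyl in place of 2-methoxyphenyl, lies at a different place and therefore gives neither size nor direction for it. No step beyond the scatter is expected in this assay, although this expectation is weakly supported. The expected step is (a 1.1-fold lower number from compound 1 to compound 3 (0.02 log units; within the scatter)). Compound 3 is estimated at (4000 nM), with an expected range from (1200 nM) to (13000 nM).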

Compound 3, half-maximal inhibitory concentration: 9200 nM
Beside the measured number, compound 3's estimate is 2.3-fold (0.36 log units) below it; low and high end bracket the measured number.
By their numbers in this assay, from the lowest: compounds 1 and 2 (each within the scatter of the next); then compound 3.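

Methoxy to hydroxy at this place on the aromatic ring gives, in this assay, a 2.2-fold higher number from compound 1 to compound 3 (0.34 log units; beyond the scatter), the only step among these compounds that lies beyond the scatter. Among the compounds shown here, the number rises modestly, towards weaker inhibition, so this position responds to losing the methyl on the oxygen, whereas 3-methoxyphenyl in place of 2-methoxyphenyl gave no step that could be read. Nothing available accounts for this rise.

The compounds shown leave open whether the other methoxy groups of the core of compound 1 respond in the same way to hydroxy, and whether the same change on compound 2 gives a step of similar size. They also leave open what an ethoxy group or an amine would give at this place.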